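Hydroxypropyl carbamoyl on the terminal amine nitrogen

This account rests on a few compounds, and the source may have more. Where it says the series, first, only, none or still open, it means among the compounds named here.

Compound 3 `COc1cc(NC(C)CCCNC(=O)NN)c2ncccc2c1` ends its chain in a free amine nitrogen. In a functional assay on L1210 cells (Mus musculus) for inhibition, read by MTT assay, with a stated time of 4 days (on this read-out lower numbers stand for stronger inhibition and higher numbers for weaker inhibition), compound 3 gives only a limit, > 250000 nM, so no number fixes where it stands. Compound 1 `COc1cc(NC(C)CCCNC(=O)NNC(=O)N(CCO)CCO)c2ncccc2c1`, carrying bis(2-hydroxyethyl)carbamoyl on that nitrogen, also gives only a limit in this assay, > 250000 nM. Within the data shown here, compound 2 `COc1cc(NC(C)CCCNC(=O)NNC(=O)Nc2ccc(Cl)c(C(F)(F)F)c2)c2ncccc2c1` gives 19000 nM in this assay; the step of an at least 13-fold lower number from compound 1 to compound 2 (1.11 log units; beyond the scatter) is the single readable step in the set, while the step that the two limits leave unreadable from compound 1 to compound 3 cannot be sized. The reference point for the unmeasured end of the set is the limit of > 250000 nM in this assay, at which 2 of the 3 values shown sit.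

Compound 4 `COc1cc(NC(C)CCCNC(=O)NNC(=O)NCCCO)c2ncccc2c1` differs from compound 3 by (3-hydroxypropyl)carbamoyl in place of hydrogen on an amine nitrogen. The entering group is a carbamoyl bearing a hydroxyalkyl chain, nearer in kind to the bis(2-hydroxyethyl)carbamoyl of compound 1 than to the (4-chloro-3-(trifluoromethyl)phenyl)amino of compound 2. Among the measured compounds shown here, no measured step bears directly on this change, and the closest analogue, compound 1, sits at the limit. The step of a number no higher from compound 3 to compound 4 (the limit leaves the size open) is therefore expected to be none that can be read. Compound 4 is expected at 250000 nM, within 80000 nM to 1000000 nM, with another limit the likeliest report.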

Compound 4, half-maximal inhibitory concentration: > 250000 nM
Compound 4: only a limit was reported; the forecaster's own chance of this, stated with the estimate: 75%; the middle value sits exactly at the limit.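

In this assay, 3-hydroxypropyl in place of 4-chloro-3-(trifluoromethyl)phenyl on an amide-type nitrogen gives an at least 13-fold higher number from compound 2 to compound 4 (1.11 log units; beyond the scatter), so a single hydroxyalkyl chain on this carbamoyl does not keep what the substituted phenyl group of compound 2 shows. The steps from compound 3 to compound 4 and from compound 1 to compound 4 cannot be read, as both ends of each are limits; the added (3-hydroxypropyl)carbamoyl therefore shows no gain that can be sized, and one hydroxyalkyl chain cannot be ranked against two. Only compound 2 gives a number, while compound 1, compound 3 and compound 4 all stay at the limit: the limit of > 250000 nM in this assay, at which 3 of the 4 values shown sit.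

From the compounds shown here alone, it stays open whether the value of compound 2 depends on the phenyl group itself or on its chloro and trifluoromethyl substituents, which an unsubstituted phenyl on the same carbonyl would separate. A longer alkyl chain without the hydroxyl, or a carboxylic acid at the chain end, would show whether any non-aromatic group on this nitrogen can leave the limit.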